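Swapping a phenyl for a methyl on the shared core

This account rests on a few compounds, and the source may have more. Where it says the series, first, only, none or still open, it means among the compounds named here.

Of the compounds shown here, two with the same core have numbers so far. In a physicochemical assay for solubility, at pH 6.8 (a lower number here means a less soluble compound, a higher number a more soluble compound), compound 1 (`Cn1cc(C(=O)N2CCN(C(=O)c3ccc(Br)cn3)[C@@H](c3ccc(Cl)cc3)C2)cc(-c2cccc(C#N)c2)c1=O`) gives 12 ug/mL and compound 2 (`O=C(c1cc(-c2cccc(C(F)(F)F)c2)c(=O)n(-c2ccccc2)c1)N1CCN(C(=O)c2ccc(Br)cn2)[C@@H](c2ccc(Cl)cc2)C1`) gives 5.9 ug/mL. That makes compound 2 the lower of the two, by a gap just beyond the usual scatter. These two differ in more than one place, so no single change has yet been measured. Compound 3 (`Cn1cc(C(=O)N2CCN(C(=O)c3ccc(Br)cn3)[C@@H](c3ccc(Cl)cc3)C2)cc(-c2cccc(C(F)(F)F)c2)c1=O`) is compound 2 with methyl in place of phenyl on an aromatic nitrogen. The 3-(trifluoromethyl)phenyl group stays. Among the measured compounds shown here, the only guide is compound 1, which carries the same methyl and gives 12 ug/mL, so a small rise in this assay is expected, perhaps none beyond the scatter. The estimated change is a 1.4-fold higher number from compound 2 to compound 3 (0.13 log units; within the scatter). For compound 3 the estimated value is 8 ug/mL, with an expected range of 3 ug/mL to 20 ug/mL.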

Compound 3, solubility: 32 ug/mL
Compound 3: the middle estimate sits 4.0-fold (0.60 log units) below what was measured; measured number above the stated range.
By their numbers in this assay, from the lowest: compound 2; then compound 1; then compound 3.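

In this assay, methyl in place of phenyl on the aromatic nitrogen gives a 5.4-fold higher number from compound 2 to compound 3 (0.73 log units; beyond the scatter) in the first single change measured at this position. A second single change, trifluoromethyl in place of cyano on an aromatic carbon, gives a 2.7-fold higher number from compound 1 to compound 3 (0.43 log units; beyond the scatter) and leaves compound 3 with the highest number of the three. Nothing available offers a reason for either step.

Going by these compounds, only methyl and phenyl appear on that nitrogen, so it remains open how an ethyl group, a longer chain or a chain ending in an amine would compare there. Also open, on these data alone, is whether the step from phenyl to methyl keeps its size when cyano stands in place of trifluoromethyl on the other aromatic ring.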